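The source may report more compounds than this note shows. Statements on the series, on what has been measured and on what is new or still open speak of the compounds shown alone.

In a functional assay for inhibition, with Homo sapiens as the target (on this read-out lower numbers stand for stronger inhibition and higher numbers for weaker inhibition), compound 1 `CCCc1nc(C)c2cnnc(O)n12` gives 56800 nM. For compound 2 `CSc1nncc2c(C)nc(C)n12` the read-out is only an assay limit, > 48000 nM. Compound 3 `CCc1nnc(O)n2c(C)nc(C)c12` likewise yields nothing but an assay limit, > 48000 nM. Compound 3 therefore stands at the limit of > 48000 nM in this assay, at which 2 of the 3 values shown sit, with no number of its own. Compound 4 `Cc1nc(C)n2c(O)nncc12` differs from compound 3 in a single place: hydrogen in place of ethyl on an aromatic carbon. Within the data shown here, no measured pair shows this change, so its size cannot be read from the data; with compound 3 already at the limit, no shift beyond the scatter in either direction is foreseen. The expected change is a step that the limit leaves unreadable from compound 3 to compound 4. Compound 4 is estimated at 70000 nM, within 25000 nM to 250000 nM, most probably reported again only as a limit.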

Compound 4, half-maximal inhibitory concentration: > 48000 nM
Compound 4: only a limit was reported; the forecaster's own chance of this, stated with the estimate: 80%; the middle value does not contradict the limit.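

Compound 4 gives only a limit, > 48000 nM, so no step linking it to compound 1, compound 2 or compound 3 can be read: the limit of > 48000 nM in this assay, at which 3 of the 4 values shown sit.

The compounds shown leave open whether any of these changes shifts the inhibition at all, and by how much.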